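The compounds below may be only part of what the source reports. "The series", "measured", "known", "first", "only" and "open" are said of these compounds alone.

Compound 1 `C=CC1=C(C(=O)NCc2ccc(Cl)cc2)C(c2ccc(OC)c(OC)c2)OC1` in a functional assay on SW480 cells (Homo sapiens) for cytotoxicity, read by MTT assay, with a stated time of 24 h (on this read-out higher numbers stand for weaker inhibition and lower numbers for stronger inhibition), gives > 100000 nM, which is a limit of the assay rather than a number.
Compound 2 `C=CC1=C(C(=O)O)C(c2ccc(OC)c(OC)c2)OC1` in this assay gives > 100000 nM, again a limit of the assay.
Compound 3 `C=CC1=C(C(=O)O)C(c2ccc(OC)cc2)OC1` in this assay gives > 100000 nM, also a limit of the assay.

Compound 2 therefore stands at the limit, and so do its two neighbours: the limit of > 100000 nM in this assay, at which 3 of the 3 values shown sit. Because of the limit of > 100000 nM in this assay, at which 3 of the 3 values shown sit, neither of the measured steps can be read: a step that the two limits leave unreadable from compound 1 to compound 2 and a step that the two limits leave unreadable from compound 2 to compound 3 give no size at all. Compound 4 `C=CC1=C(C(=O)NCc2ccccc2)C(c2ccc(OC)c(OC)c2)OC1` has not yet been measured. It differs from compound 2 in one place: benzylamino in place of hydroxy on a carbonyl carbon. The step that the two limits leave unreadable from compound 1 to compound 2 touches this same carbonyl carbon, and compound 1, which carries a closely related group there, also sits at the limit. The measured steps thus give no hint of a step beyond the scatter in either direction, so nothing more than the scatter is expected in this assay. Compound 4 is expected to give 150000 nM, between 50000 nM and 500000 nM, most likely reported as a limit once more. The step this estimate means, a step that the limit leaves unreadable from compound 2 to compound 4, is expected to lie within the scatter.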

Compound 4, half-maximal inhibitory concentration: > 100000 nM
Compound 4: a limit, no number; the forecaster's own chance of this, stated with the estimate: 85%; the middle value is on the limit's open side.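

For the compounds shown here, no step to compound 4 can be read, either from compound 2 or from compound 1, because every compound shown sits at the same limit: the limit of > 100000 nM in this assay, at which 4 of the 4 values shown sit. The compounds shown leave open what change to them, if any, would give a measurable value in this assay.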